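The source may hold more compounds than are shown below. What is called first, only, known or untested is meant among the compounds shown, and "the series" means these compounds.

Compound 1 `CC(O)Cn1nnnc1-c1ccccc1-c1ccc(CN2C(=O)[C@H](NC(=O)CC(C)(C)N)CCc3ccccc32)cc1` and compound 2 `CC(C)(N)CC(=O)N[C@@H]1CCc2ccccc2N(Cc2ccc(-c3ccccc3-c3nnn(Cc4ccccc4)n3)cc2)C1=O` share one core and differ only in the group carried on an aromatic carbon. Among the measured compounds shown here, in a functional assay (Pituitary gland cell) with Rattus norvegicus as the target (a higher number here means that more compound is needed for the effect, a lower number that less compound is needed), compound 1 gives 0.05 uM, while compound 2 gives 1 uM; the single step observed, a 20-fold higher number from compound 1 to compound 2 (1.30 log units; beyond the scatter), therefore shows that compound 2 stands at the highest number of the two, needing the most compound for the effect.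

Compound 3 `Cn1nnnc1-c1ccccc1-c1ccc(CN2C(=O)[C@H](NC(=O)CC(C)(C)N)CCc3ccccc32)cc1` is not yet measured. It differs from compound 2 by 1-methyl-1H-tetrazol-5-yl in place of 2-benzyl-2H-tetrazol-5-yl on an aromatic carbon. For the measured compounds named here, the one step that bears on this change is a 20-fold higher number from compound 1 to compound 2 (1.30 log units; beyond the scatter), in which the 2-benzyl-2H-tetrazol-5-yl group was paired with the much higher number. Compound 3 returns to a 1-substituted tetrazole, as in compound 1, though it carries only a methyl rather than a 2-hydroxypropyl. Because compound 1 with its 1-substituted tetrazole gives 0.05 uM, the author expects compound 3 to move back toward that number, with a step of about a 10-fold lower number from compound 2 to compound 3 (1.00 log units; beyond the scatter) in this assay. The estimate for compound 3 is thus 0.1 uM, within a range from 0.03 uM to 0.4 uM, with the change in direction expected to lie beyond the scatter.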

Compound 3, concentration for half-maximal effect: 0.5 uM
For compound 3 the middle estimate is 5.0-fold (0.70 log units) below the measured one, and the stated range ends below it.
By their numbers in this assay, from the lowest: compound 1; then compounds 3 and 2 (each within the scatter of the next).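

The exchange of 2-benzyl-2H-tetrazol-5-yl for 1-methyl-1H-tetrazol-5-yl, on an aromatic carbon ortho to a large group, gives a 2.0-fold lower number from compound 2 to compound 3 (0.30 log units; within the scatter) in this assay and so moves the number by no more than the scatter. A 1-substituted tetrazole therefore does not by itself go with a low number, and the large gap first seen between compound 1 and compound 2 cannot be assigned to the tetrazole substitution pattern alone. The chain on the tetrazole nitrogen matters instead. The 1-hydroxyethyl part of the 2-hydroxypropyl chain is lost, with the rest of the molecule unchanged, and a 10-fold higher number from compound 1 to compound 3 (1.00 log units; beyond the scatter) goes with this loss.

On these data alone, it remains open whether the hydroxyl group or the chain length goes with the low number of compound 1, which a plain propyl chain or a 2-hydroxyethyl chain on the same nitrogen could help to separate. As far as these compounds go, it is also open whether a 2-methyl or 1-benzyl tetrazole would follow the attachment pattern or the size of the group. Nothing in the data explains either step.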